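The compounds below may be only part of what the source reports. "The series", "measured", "known", "first", "only" and "open" are said of these compounds alone.

In an ADME assay on cells (Epithelial cell, Homo sapiens) for antiproliferative activity, read by MTT assay, with a stated time of 48 h (on this read-out lower numbers stand for stronger inhibition and higher numbers for weaker inhibition), compound 1 (`COC(=O)/C(=C/c1ccccc1)CN1C(=O)[C@@H](OC)[C@H]1c1cccc(Cl)c1`) has no number: it is reported as "not toxic" (no number reported). Compound 2 (`COc1ccc(OC)c([C@@H]2[C@H](OC)C(=O)N2C/C(C#N)=C/c2ccccc2)c1`) gives > 100000 nM, which is a limit of the assay and not a number. Compound 3 (`COC(=O)/C(=C/c1ccccc1)CN1C(=O)[C@@H](OC)[C@H]1c1cccc([N+](=O)[O-])c1`) carries nitro in place of chloro on an aromatic carbon of compound 1, meta to a large group: nitro in place of chloro on an aromatic carbon. For the measured compounds named here, no measured pair shows what this swap does. With compound 1 at "not toxic" (no number reported), no step beyond the usual scatter is expected in this assay, in either direction. Compound 3 is estimated at 100000 nM, within a range from 30000 nM to 200000 nM, and may well be reported only as a limit.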

Compound 3, half-maximal inhibitory concentration: "not toxic" (no number reported)
No number was reported for compound 3, so the estimate cannot be set against anything.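

Compound 1 and compound 3 are both reported as "not toxic" without a number, so no step can be read between them. Whether 3-chlorophenyl to 3-nitrophenyl changes anything in this assay stays open, since no compound shown has an exact number, only words or a limit: the limit of > 100000 nM in this assay, at which 1 of the 3 values shown sits.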